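Swapping the Amide Aryl Group on a Shared Core

The source may report more compounds than this note shows. Statements on the series, on what has been measured and on what is new or still open speak of the compounds shown alone.

Three compounds share one core and differ only in the aromatic group on the amide carbonyl. Compound 1 `COc1cccc(C(=O)Nc2cccc(-c3oc4cc(-c5ccc(F)cc5)ccc4c(=O)c3O)c2)c1` gives 9950 nM in a functional assay on HepG2 cells (Homo sapiens) for antiproliferative activity, read by CCK-8 assay, with a stated time of 72 h; a higher number here means a weaker inhibitor, a lower number a stronger inhibitor. Compound 2 `COc1cc(OC)cc(C(=O)Nc2cccc(-c3oc4cc(-c5ccc(F)cc5)ccc4c(=O)c3O)c2)c1` gives 23500 nM, and compound 3 `Cc1cc(C)cc(C(=O)Nc2cccc(-c3oc4cc(-c5ccc(F)cc5)ccc4c(=O)c3O)c2)c1` gives 13400 nM. On these numbers compound 3 stands second highest, but its gaps to compound 1 and to compound 2 both lie within the usual scatter, so no ranking among them can be claimed. Compound 4 `O=C(Nc1cccc(-c2oc3cc(-c4ccc(F)cc4)ccc3c(=O)c2O)c1)c1ccc(Cl)nc1` carries the change (6-chloropyridin-3-yl in place of 3,5-dimethylphenyl on a carbonyl carbon). Within the data shown here, no measured step introduces a ring nitrogen or a chlorine; the closest comparisons, a 1.3-fold higher number from compound 1 to compound 3 (0.13 log units; within the scatter) and a 1.8-fold lower number from compound 2 to compound 3 (0.24 log units; within the scatter), were small, while a 2.4-fold higher number from compound 1 to compound 2 (0.37 log units; beyond the scatter) was modest. Compound 4 is therefore expected to shift only by a 1.1-fold lower number from compound 3 to compound 4 (0.05 log units; within the scatter). The estimated value for compound 4 is 12000 nM, with a range from 5000 nM to 30000 nM.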

Compound 4, half-maximal inhibitory concentration: 4610 nM
For compound 4 the middle estimate is 2.6-fold (0.42 log units) above the measured one; the whole stated range lies above it.
By their numbers in this assay, from the lowest: compound 4; then compounds 1, 3 and 2 (each within the scatter of the next, the first and the last beyond it).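

Replacing the phenyl ring on the amide carbonyl with 6-chloropyridin-3-yl lowers the number in all three comparisons, with a 2.9-fold lower number from compound 3 to compound 4 (0.46 log units; beyond the scatter) and a 5.1-fold lower number from compound 2 to compound 4 (0.71 log units; beyond the scatter) and a 2.2-fold lower number from compound 1 to compound 4 (0.33 log units; beyond the scatter), making compound 4 the strongest of the four. This position therefore tolerates a ring with a nitrogen, and this change moves the number further than swapping methoxy and methyl groups on a phenyl ring did. Nothing measured here accounts for the gain.

The ring nitrogen and the chlorine enter together, leaving open which of them matters. An unsubstituted pyridin-3-yl, a chlorophenyl or an amine on this ring would help separate them.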